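Methylphenyl replaces fluoropyridinyl on a shared core

The source may hold more compounds than are shown below. What is called first, only, known or untested is meant among the compounds shown, and "the series" means these compounds.

Compound 3 `N#CCCCn1c(Cn2c(=O)n(-c3ccncc3F)c3ccncc32)cc2cc(Cl)ccc21` sits at a limit in an ADME assay on HeLa cells (Homo sapiens) for cytotoxicity, read by ATP content, with a stated time of 3 days; on this read-out lower numbers stand for higher toxicity in this test and higher numbers for lower toxicity in this test: in this assay compound 3 gives > 50000 nM, which is a limit of the assay and not a number. The two compounds around it are no different in kind. Compound 1 `COc1ccc(-n2c(=O)n(Cc3cc4cc(Cl)ccc4n3CCCC#N)c3cnccc32)cc1` gives in this assay > 50000 nM, a limit. Compound 2 `N#CCCCn1c(Cn2c(=O)n(-c3ccc(C(=O)O)cc3)c3ccncc32)cc2cc(Cl)ccc21` gives in this assay > 50000 nM, again a limit. So the limit of > 50000 nM in this assay, at which 3 of the 3 values shown sit, sums up all that the three values show, and the steps a step that the two limits leave unreadable from compound 1 to compound 2, a step that the two limits leave unreadable from compound 1 to compound 3 and a step that the two limits leave unreadable from compound 2 to compound 3 have no readable size. Compound 4 `Cc1ccc(-n2c(=O)n(Cc3cc4cc(Cl)ccc4n3CCCC#N)c3cnccc32)cc1` differs from compound 3 by 4-methylphenyl in place of 3-fluoropyridin-4-yl on an aromatic nitrogen. Within the data shown here, no measured step bears readably on this exchange; the two earlier changes at the same aromatic nitrogen, and the one at an aromatic carbon, all left the read-out at the limit. The analyst therefore expects no step beyond the scatter, the estimated step being a number no higher from compound 3 to compound 4 (the limit leaves the size open). For compound 4 in this assay the analyst estimates 50000 nM, within 20000 nM to 120000 nM, most probably reported once more only as a limit.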

Compound 4, half-maximal cytotoxic concentration: > 50000 nM
Compound 4 ended at the assay's limit; the forecaster's own chance of this, stated with the estimate: 85%; the middle value lies on the limit itself.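

In this assay compound 4 gives > 50000 nM, a limit and not a number. Among these compounds, no step linking compound 4 with compound 1, compound 2 or compound 3 can be read. The compounds shown leave open how toxic any of these four is in this test, and whether any of the exchanges changes that toxicity at all.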